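Enone pyrazoles: aryl swap on the carbonyl carbon

The source may hold more compounds than are shown below. What is called first, only, known or untested is meant among the compounds shown, and "the series" means these compounds.

Among the measured compounds shown here, compound 2 `COc1ccc(C(=O)/C=C/c2cc(-c3cc(OC)c(OC)c(OC)c3)n[nH]2)cc1` gives 1720 nM in a functional assay on SK-MEL-5 cells (Homo sapiens) for inhibition, read by sulforhodamine B assay, with a stated time of 48 h (a higher number here means a weaker inhibitor of growth, a lower number a stronger inhibitor of growth), the lowest of the two numbers so far. For the measured compounds named here, compound 1 `COc1cc(-c2cc(/C=C/C(=O)c3ccc(Cl)c(Cl)c3)[nH]n2)cc(OC)c1OC`, which carries a 3,4-dichlorophenyl on the carbonyl carbon, gives 13400 nM in this assay, and the step of a 7.8-fold lower number from compound 1 to compound 2 (0.89 log units; beyond the scatter) is the only measured step. Compound 3 `COc1cc(-c2cc(/C=C/C(=O)c3ccc(F)c(F)c3)[nH]n2)cc(OC)c1OC` differs from compound 2 by 3,4-difluorophenyl in place of 4-methoxyphenyl on a carbonyl carbon. This change runs back toward the dihalogenated aryl of compound 1, so the step from compound 1 to compound 2 bears on it directly, in reverse. Going by these compounds, whether two fluorines behave like two chlorines here is untested, so the magnitude is uncertain, but the direction is expected to be a higher number. Going by the values given here, compound 3 is therefore estimated at 8000 nM in this assay, with a range of 2500 nM to 25000 nM, which means an expected step of a 4.7-fold higher number from compound 2 to compound 3 (0.67 log units; beyond the scatter) because the reverse of a 7.8-fold lower number from compound 1 to compound 2 (0.89 log units; beyond the scatter) is the only guide available.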

Compound 3, concentration for 50% growth inhibition: 2270 nM
Estimate against measurement, compound 3: 3.5-fold (0.55 log units) above; measured number outside the range, below it.
By their numbers in this assay, from the lowest: compounds 2 and 3 (each within the scatter of the next); then compound 1.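

Working notes: in this assay, the carbonyl carbon accepts 3,4-difluorophenyl and 4-methoxyphenyl without a distinction between them, with a 1.3-fold higher number from compound 2 to compound 3 (0.12 log units; within the scatter), so a dihalogenated aryl at this place does not by itself go with the high number seen for compound 1. Among the compounds shown here, the identity of the halogen separates the two dihalogenated compounds, with a 5.9-fold lower number from compound 1 to compound 3 (0.77 log units; beyond the scatter), and this exchange of 3,4-dichlorophenyl for 3,4-difluorophenyl is the first sign that the two halogen pairs are not interchangeable on this carbonyl carbon. Nothing available accounts for that gap or for the match between compound 2 and compound 3.

Going by these compounds, all three compounds share the rest of the core, so these readings describe only this one place, and whether the same ranking would hold with a different group elsewhere on the core remains open. Also open, on these data alone, is how a phenyl carrying a single fluorine, an amine or a carboxylic acid would read on this carbonyl carbon, and whether any such group would move the number beyond the scatter of compound 2 and compound 3.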